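Methyl in Place of Cyano: A Loss Expected

The source may hold more compounds than are shown below. What is called first, only, known or untested is meant among the compounds shown, and "the series" means these compounds.

Of the compounds shown here, two have so far been measured in a functional assay on NUGC-3 cells (Homo sapiens) for antiproliferative activity, read by sulforhodamine B assay; on this read-out higher numbers stand for weaker inhibition of growth and lower numbers for stronger inhibition of growth. Compound 1, `COc1ccc2sc(NC(=O)c3ccc(C)cc3)nc2c1`, does not give a number: in this assay compound 1 gives > 10 ug/mL, which is a limit of the assay, namely (the limit of > 10 ug/mL in this assay, at which 1 of the 2 values shown sits). Among the compounds with values here, compound 2, `Cc1cc(C)c2sc(NC(=O)c3ccc(C#N)cc3)nc2c1`, gives 0.62 ug/mL in this assay, the only finite number in the set, so it stands as the single measured point of reference for growth inhibition here.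

Compound 3, `Cc1ccc(C(=O)Nc2nc3cc(C)cc(C)c3s2)cc1`, differs from compound 2 in one place: methyl in place of cyano on an aromatic carbon, in words methyl in place of cyano on an aromatic carbon. Compound 1 also carries a methyl on that ring, but its shared core differs from that of compound 3, so the two values of compound 1 and compound 2 show only that one combination sits at the limit while the other does not. Within the data shown here, they do not fix how large the single swap will be.

The expected step is a 4.8-fold higher number from compound 2 to compound 3 (0.68 log units; beyond the scatter), a weakening beyond the usual scatter, with a real chance that only a limit is reported. Compound 3 is estimated at 3 ug/mL, between 0.8 ug/mL and 10 ug/mL.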

Compound 3, concentration for 50% growth inhibition: 2.37 ug/mL
The estimate for compound 3 lay 1.3-fold (0.10 log units) above the measured number; low and high end bracket the measured number.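

In this assay, within the data shown here, putting methyl in place of cyano on an aromatic carbon, para to a large group, gives a 3.8-fold higher number from compound 2 to compound 3 (0.58 log units; beyond the scatter), the first change in this set whose size can be read as a single swap. Growth inhibition therefore depends on which of these two groups sits at this place, though the change is modest: compound 3 gives 2.37 ug/mL, still a finite number rather than a limit of the assay. Among these compounds, nothing measured so far bears on what lies behind this step.

Among the compounds shown here, only two groups can be compared at this place, so it remains open whether a carboxylic acid, an amine or a longer chain such as ethyl would land near compound 2, near compound 3 or beyond both. Compound 1 gives > 10 ug/mL, which is a limit of the assay and not a number, and because its core also differs, the part played by the groups on the core stays open too: the limit of > 10 ug/mL in this assay, at which 1 of the 3 values shown sits.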